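The source may hold more compounds than are shown below. What is called first, only, known or untested is meant among the compounds shown, and "the series" means these compounds.

Measured compounds:
Compound 1, `Cc1ccsc1/C(=C/CCCCC(=O)O)c1cccnc1`: 29 nM
Compound 2, `O=C(O)CCCC/C=C(\c1cccnc1)c1cccc(F)c1`: 55 nM

The two compounds have been measured in an assay (Equus caballus) for inhibition of Thromboxane-A synthase (Homo sapiens), using microsomes; a lower number here means a stronger inhibitor, a higher number a weaker inhibitor. Among the measured compounds shown here, compound 2 gives 55 nM and compound 1 gives 29 nM; the only step that joins them, a 1.9-fold higher number from compound 1 to compound 2 (0.28 log units; within the scatter), lies within the scatter, so the two values cannot be told apart.

Compound 3, `O=C(O)CCCC/C=C(\c1cccnc1)c1ccsc1`, has not yet been measured. It differs from compound 2 in one place: thiophen-3-yl in place of 3-fluorophenyl on a double-bonded chain carbon bound to an aromatic carbon and a double-bonded chain carbon. For the measured compounds named here, the one measured step that bears on it is the exchange of one aromatic group for another at the same place, a 1.9-fold higher number from compound 1 to compound 2 (0.28 log units; within the scatter), which did not move the number beyond the scatter. Since that earlier exchange of ring types at this position left the value essentially unchanged, compound 3 is expected to stay close to compound 2, with no step beyond the scatter, and its value in this assay is estimated at 40 nM, within a range of 15 nM to 120 nM, which corresponds to an expected step of a 1.4-fold lower number from compound 2 to compound 3 (0.14 log units; within the scatter).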

Compound 3, half-maximal inhibitory concentration: 31 nM
For compound 3 the middle estimate is 1.3-fold (0.11 log units) above the measured one, within the range that was stated.
By their numbers in this assay, from the lowest: compounds 1, 3 and 2 (each within the scatter of the next).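

Across the three compounds in this assay, this place on the double-bonded chain carbon has held three different aromatic groups with no step beyond the scatter. Exchanging 3-fluorophenyl for thiophen-3-yl gives a 1.8-fold lower number from compound 2 to compound 3 (0.25 log units; within the scatter) and so shows that a five-membered aromatic ring with one sulfur can replace the six-membered carbon ring bearing fluorine, while exchanging 3-methylthiophen-2-yl for the same group gives a 1.1-fold higher number from compound 1 to compound 3 (0.03 log units; within the scatter) and shows that a thiophene ring without the methyl group cannot be told apart from the methylated one. No measurement shown here explains why these groups give such similar values.

As far as these compounds go, all three groups at this place are aromatic rings, so it remains open how a cyclohexyl ring or a single methyl group would read there. From the compounds shown here alone, the effect of a longer chain carrying the carboxylic acid also remains open.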